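The compounds below may be only part of what the source reports. "The series", "measured", "known", "first", "only" and "open" are said of these compounds alone.

Compound 2, `CCCC(C)Nc1nc(N)nc2cccnc12`, gives 3100 nM in an assay on tissue (PBMC cells) for agonist activity at Toll-like receptor 8 (Homo sapiens), with a stated time of 24 h; on this read-out higher numbers stand for an effect only at larger amounts of compound and lower numbers for an effect already at smaller amounts. Among the two measured compounds it holds the highest number, and its nearest neighbour is compound 1, `CCCCNc1nc(N)nc2cccnc12`, which in this assay gives 1900 nM. Among the compounds with values here, the one measured step, a 1.6-fold higher number from compound 1 to compound 2 (0.21 log units; within the scatter), lies within the scatter, so the two compounds show no separable difference.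

Compound 3, `CCC[C@H](CO)Nc1nc(N)nc2cccnc12`, is not yet measured. It differs from compound 2 by 1-(hydroxymethyl)butyl in place of 1-methylbutyl on a nitrogen on an aromatic ring. Within the data shown here, no measured step touches this change: the only step known concerns a methyl on the same saturated chain carbon, and it stayed within the scatter. The expectation for compound 3 therefore rests mainly on the value of compound 2, 3100 nM, with a wide range around it. Compound 3 is estimated at 800 nM in this assay, between 150 nM and 4000 nM, which corresponds to an expected step of a 3.9-fold lower number from compound 2 to compound 3 (0.59 log units; beyond the scatter).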

Compound 3, half-maximal effective concentration: 19000 nM
The estimate for compound 3 lay 24-fold (1.38 log units) below the measured number, and the stated range ends below it.
By their numbers in this assay, from the lowest: compounds 1 and 2 (each within the scatter of the next); then compound 3.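

On the saturated chain carbon bound to the nitrogen on an aromatic ring, the methyl of compound 2 had brought no separable difference in this assay, but the position is not indifferent to what it carries: 1-(hydroxymethyl)butyl in place of 1-methylbutyl gives (a 6.1-fold higher number from compound 2 to compound 3 (0.79 log units; beyond the scatter)). The same holds against the unbranched chain, where hydroxymethyl in place of hydrogen gives (a 10-fold higher number from compound 1 to compound 3 (1.00 log units; beyond the scatter)), so adding a hydroxymethyl at this carbon, unlike adding a methyl, moves the number beyond the scatter. Nothing at hand explains this shift.

On these data alone, it remains open whether the change belongs to the hydroxyl itself or to the defined stereocentre, which the mirror-image form of compound 3 would separate. A methoxymethyl, an aminomethyl or a longer hydroxyalkyl chain at this carbon also remains to be read.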